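A Fluorine Added at the Phenoxy End

A few compounds are considered here, and "the series" means these few. Any claim that something is new, unique, unknown or untested is made for them only; others in the source may bear on it.

Measured so far:
Compound 1 `Cc1c(OCCCCOc2ccc(-n3cncn3)cc2)ccc(C(=O)CC(C)C)c1O` gives 4240 nM in a functional assay for binding affinity to metabotropic glutamate receptor 2 (Homo sapiens), read by GTPgammaS binding; a higher number here means that more compound is needed for the effect, a lower number that less compound is needed.
Compound 2 `Cc1c(OCCCCOc2ccccc2)ccc(C(=O)CC(C)C)c1O` gives 4550 nM in this assay.

Among these two numbers compound 2 stands highest, with compound 1 nearest; the only measured step, a 1.1-fold higher number from compound 1 to compound 2 (0.03 log units; within the scatter), lies within the scatter, so the two compounds cannot be told apart by this reading.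

Compound 3 `Cc1c(OCCCCOc2ccccc2F)ccc(C(=O)CC(C)C)c1O` is the unmeasured analogue. It differs from compound 2 by fluoro in place of hydrogen on an aromatic carbon.

Within the data shown here, only one measured step exists, and it bears on compound 3 merely in that it also alters the same ring at the phenoxy end without moving the number beyond the scatter. Among the measured compounds shown here, no measured step involves fluoro itself, so nothing in the data points to a change in either direction. The expectation for compound 3 is therefore a step of about a 1.1-fold lower number from compound 2 to compound 3 (0.06 log units; within the scatter), that is, none beyond the scatter. Compound 3 is estimated to give 4000 nM in this assay, within a range of 1500 nM to 11000 nM.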

Compound 3, half-maximal effective concentration: 1990 nM
For compound 3 the middle estimate is 2.0-fold (0.30 log units) above the measured one; measured number inside the range.
By their numbers in this assay, from the lowest: compound 3; then compounds 1 and 2 (each within the scatter of the next).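

Fluoro in place of hydrogen, ortho to a large group on the phenoxy ring, gives a 2.3-fold lower number from compound 2 to compound 3 (0.36 log units; beyond the scatter) in this assay and so produces the first measured step in this set that lies beyond the scatter, though a modest one. Among these compounds, the earlier step on this ring, which exchanged 1H-1,2,4-triazol-1-yl for hydrogen, stayed within the scatter, so this is the first sign that a change to the phenoxy ring can shift the number at all, and a single fluorine atom is enough to do so. No measurement shown here accounts for this step.

As far as these compounds go, it remains open whether chloro, methyl or methoxy at the same place would lower the number as fluoro does, or whether fluoro at other places on the ring would do the same. Also open, from the compounds shown here alone, is whether the step would survive a longer chain carrying the phenoxy group.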